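From nitro to hydroxy: what to expect for compound 3

This account rests on a few compounds, and the source may have more. Where it says the series, first, only, none or still open, it means among the compounds named here.

Compound 1 (`COC(=O)c1c(-c2ccc([N+](=O)[O-])cc2)oc2ccccc2c1=O`) gives > 25 ug/mL in a functional assay on SK-MEL cells (Homo sapiens) for cytotoxicity, read by MTT assay, with a stated time of 6 days (on this read-out lower numbers stand for an effect already at smaller amounts and higher numbers for an effect only at larger amounts of compound), and this is a limit of the assay, not a number. Compound 2 (`COC(=O)c1c(-c2ccc([N+](=O)[O-])cc2)oc2cc(OC)ccc2c1=O`) gives 2.84 ug/mL in this assay. Going by the values given here, the only measured step is an at least 8.8-fold lower number from compound 1 to compound 2 (0.94 log units; beyond the scatter), made by methoxy in place of hydrogen on an aromatic carbon. Compound 3 (`COC(=O)c1c(-c2ccc(O)cc2)oc2ccccc2c1=O`) instead carries hydroxy in place of nitro on an aromatic carbon, para to a large group: hydroxy in place of nitro on an aromatic carbon. Among the compounds with values here, the measured step involves a different swap at a different place, so it shows only that a single change can matter here and gives no direction for this one. The expected step is therefore small, not clearly beyond the scatter: an at least 1.3-fold lower number from compound 1 to compound 3 (0.14 log units; that floor lies within the scatter). For compound 3 the estimated value is 18 ug/mL, with an expected range from 5 ug/mL to 40 ug/mL.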

Compound 3, concentration for half-maximal effect: > 25 ug/mL
Compound 3: no number, only a limit; the forecaster's own chance of this, stated with the estimate: 55%; at least 1.3-fold (0.14 log units) between middle value and limit.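

In this assay compound 3 gives > 25 ug/mL as a limit of the assay, not a number. Going by these compounds alone, compound 1 also stands at a limit, so no step between compound 1 and compound 3 can be read: the limit of > 25 ug/mL in this assay, at which 2 of the 3 values shown sit.

The compounds shown leave open whether hydroxy in place of nitro changes the number at all, and in which direction.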